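A few compounds are considered here, and "the series" means these few. Any claim that something is new, unique, unknown or untested is made for them only; others in the source may bear on it.

Measured compounds:
Compound 1 `Cc1ccc(NC(=O)c2ccc([N+](=O)[O-])o2)cc1` gives 6700 nM in a functional assay on HCC1806 cells (Homo sapiens) for cytotoxicity, read by CellTiter-Glo, with a stated time of 3 days; a lower number here means a stronger inhibitor, a higher number a weaker inhibitor.
Compound 2 `CCc1ccc(NC(=O)c2ccc([N+](=O)[O-])o2)cc1` gives 5000 nM in this assay.

Both compounds share the same core and differ only in the group carried by the six-membered aromatic ring of carbon only. For the measured compounds named here, the single measured step, a 1.3-fold lower number from compound 1 to compound 2 (0.13 log units; within the scatter), is within the usual scatter, so the two numbers cannot be told apart with confidence; compound 2 simply sits at one end of a pair that the assay does not separate.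

Compound 3 `O=C(Nc1ccc(Cl)cc1)c1ccc([N+](=O)[O-])o1` has not yet been measured. It differs from compound 2 by chloro in place of ethyl on an aromatic carbon. Going by the values given here, no measured step involves a chloro group, and the only step available, from methyl to ethyl, moved the number hardly at all. Among the compounds with values here, the change to chloro is of a different kind, so the one known step gives only weak guidance. On the evidence present, the expectation for this assay is a step of modest size at most, with no firm direction, and quite possibly none beyond the scatter.

Compound 3 is therefore estimated at 4500 nM, with a range from 1500 nM to 14000 nM, which corresponds to an expected step of a 1.1-fold lower number from compound 2 to compound 3 (0.05 log units; within the scatter).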

Compound 3, half-maximal inhibitory concentration: 5100 nM
The estimate for compound 3 lay 1.1-fold (0.05 log units) below the measured number; measured number inside the range.
By their numbers in this assay, from the lowest: compounds 2, 3 and 1 (each within the scatter of the next).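

In this assay, chloro in place of ethyl gives a 1.0-fold higher number from compound 2 to compound 3 (0.01 log units; within the scatter) and chloro in place of methyl gives a 1.3-fold lower number from compound 1 to compound 3 (0.12 log units; within the scatter); neither step can be told apart from the differences seen between repeated measurements. For the compounds shown here, the earlier pair compared only two carbon groups, whereas this result adds a group built on a chlorine atom at the same place, on an aromatic carbon para to a large group, and the three numbers still cannot be separated. For methyl, ethyl and chloro, then, the identity of the group at this position makes no difference that this assay can resolve, although that finding covers only these three groups, and no measurement shown here offers an explanation for it.

The compounds shown leave open whether any other group at this position would stand clearly apart from these three, such as an amine, a carboxylic acid or a longer chain like butyl. They also leave open how much the rest of the shared core contributes to the number, including the nitro group and the amide, which are the same in all three compounds.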